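Trifluoromethyl Replaces Ethyl on the Sulfonyl Sulfur

A few compounds are considered here, and "the series" means these few. Any claim that something is new, unique, unknown or untested is made for them only; others in the source may bear on it.

Compound 1, `Cc1cc(NC(=O)c2cc(C(F)(F)F)cc(C(F)(F)F)c2)ccc1NS(=O)(=O)C(F)(F)F`, in an ADME assay on RAW264.7 cells (Mus musculus) for cytotoxicity, read by MTT assay, with a stated time of 48 h (a higher number here means a weaker inhibitor, a lower number a stronger inhibitor), gives 40700 nM.
Compound 2, `COc1cc(NC(=O)c2cc(C(F)(F)F)cc(C(F)(F)F)c2)ccc1NS(=O)(=O)C(F)(F)F`, in this assay gives > 250000 nM, which is a limit of the assay and not a number.
Compound 3, `CCS(=O)(=O)Nc1ccc(NC(=O)c2cc(C(F)(F)F)cc(C(F)(F)F)c2)cc1F`, in this assay gives > 250000 nM, again a limit rather than a number.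

Among the three, compound 1 is the only one with a number, and the single measured step is an at least 6.1-fold higher number from compound 1 to compound 2 (0.78 log units; beyond the scatter). Compound 3 therefore stands at the edge of what the assay can report, and much of the picture is fixed by the limit of > 250000 nM in this assay, at which 2 of the 3 values shown sit. Compound 4, `O=C(Nc1ccc(NS(=O)(=O)C(F)(F)F)c(F)c1)c1cc(C(F)(F)F)cc(C(F)(F)F)c1`, differs from compound 3 by trifluoromethyl in place of ethyl on a sulfonyl sulfur. Among the compounds with values here, no measured step alters the group on the sulfonyl sulfur, so none of them bears directly on this change; the nearest point of comparison is compound 1, which carries the same (trifluoromethyl)sulfonyl group and gives a number at 40700 nM. Compound 4 is expected to remain a weak inhibitor, with a step of an at least 2.0-fold lower number from compound 3 to compound 4 (0.31 log units; beyond the scatter) expected, though compound 3 having only a limit makes the size uncertain. Compound 4 is estimated at 120000 nM, within 40000 nM to 250000 nM, with a fair chance that only a limit is reported again.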

Compound 4, half-maximal inhibitory concentration: 112000 nM
Estimate against measurement, compound 4: 1.1-fold (0.03 log units) above; the range from low to high includes it.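

Within the data shown here, compound 4 gives the first number in this assay for a compound with fluoro on this aromatic carbon, and with it the change at the sulfonyl sulfur can be read for the first time, as an at least 2.2-fold lower number from compound 3 to compound 4 (0.34 log units; beyond the scatter). With the (trifluoromethyl)sulfonyl group held constant, the aromatic carbon now has three groups to compare: fluoro in place of methoxy gives an at least 2.2-fold lower number from compound 2 to compound 4 (0.34 log units; beyond the scatter), and fluoro in place of methyl gives a 2.8-fold higher number from compound 1 to compound 4 (0.44 log units; beyond the scatter), so the number for fluoro lies over that for methyl and under the limit for methoxy. The two steps that start from a limit give only a smallest size and not a full one: the limit of > 250000 nM in this assay, at which 2 of the 4 values shown sit.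

From the compounds shown here alone, whether the change from ethyl to trifluoromethyl on the sulfonyl sulfur has the same size with methyl or methoxy on the aromatic carbon stays open, since it is read here only with fluoro. Also open, going by these compounds, is how chloro on the aromatic carbon, or a longer chain such as propyl on the sulfonyl sulfur, would read in this assay.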